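The source may hold more compounds than are shown below. What is called first, only, known or untested is meant among the compounds shown, and "the series" means these compounds.

Compound 1 `CCc1ccc(-n2cc(COc3ccc4c(c3)CCC4)nn2)cc1`: "not determined" (no result reported) in an ADME assay on HEK293 cells (Homo sapiens) for inhibition, read by MTT assay, with a stated time of 48 h, tested at 25 uM; a lower number here means less inhibition, a higher number more inhibition at the concentration tested (going by the name of the read-out)
Compound 2 `Cc1cccc(-n2cc(COc3ccc4c(c3)CCC4)nn2)c1`: 23.4%
Compound 3 `Brc1ccc(-n2cc(COc3ccc4c(c3)CCC4)nn2)cc1`: "not determined" (no result reported)

Three compounds share one core and differ only in the group carried on the outer phenyl ring. Compound 3 stands without a single number in this assay, and it is not alone: compound 1 is a further entry without a number. The only figure that exists comes from compound 2, which gives 23.4% in this assay, a modest degree of inhibition.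

The new compound, compound 4 `COc1ccc(-n2cc(COc3ccc4c(c3)CCC4)nn2)cc1`, follows from compound 3 through one change: methoxy in place of bromo on an aromatic carbon. Among the compounds with values here, no step between measured compounds is available to guide what this change does, and compound 3 itself offers no starting value. Within the data shown here, with only the single modest number of compound 2 as a reference, the expectation for compound 4 in this assay is a result of similar size, with no step expected beyond the usual scatter in either direction. Compound 4 is therefore estimated to give 25% in this assay, with a range from 5% to 50%.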

Compound 4, a percentage reported as inhibition, at one concentration (the size of the read-out at that concentration, not a potency): 21.1%
Compound 4: the middle estimate sits 3.9 percentage points above what was measured; the measured number falls inside the stated range.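

With compound 4, the series gains a second number in this assay and its first readable step: a number 2.3 percentage points lower from compound 2 to compound 4 (within the scatter). On the outer phenyl ring of the shared core, 4-methoxyphenyl and 3-methylphenyl therefore cannot be told apart in this read-out, although the two differ in both the group and its place on the ring. The steps involving compound 1 or compound 3, including bromo to methoxy, cannot be read, and no measurement shown gives a cause for the closeness of compound 2 and compound 4.

Going by these compounds, it remains open whether an amine or a carboxylic acid on this ring would shift the inhibition beyond the usual scatter. The same question stands for a longer chain, such as butyl, and for the effect of any change to the shared core itself.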